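The source may report more compounds than this note shows. Statements on the series, on what has been measured and on what is new or still open speak of the compounds shown alone.

Measured so far in a toxicity assay on NIH3T3 cells (Mus musculus) for cytotoxicity, read by resazurin assay; a lower number here means that less compound is needed, a higher number that more compound is needed for the effect:
- compound 1 `Cc1cccc(-c2cccc(NCc3cncn3Cc3ccccc3)c2)c1C`: > 1000 nM
- compound 2 `Cc1ccc(Cn2cncc2CNc2cccc(-c3ccccc3)c2)cc1`: 10000 nM
- compound 3 `CS(=O)(=O)c1ccc(Cn2cncc2CNc2ccc(-c3nc4ccccc4s3)c(-c3ccccc3)c2)cc1`: > 1000 nM

Compound 1 has no exact number, and its value of > 1000 nM is a limit of the assay. Compound 3 also gives only a limit, > 1000 nM. Together these two compounds make up (the limit of > 1000 nM in this assay, at which 2 of the 3 values shown sit). Among the compounds with values here, the only true number comes from compound 2, at 10000 nM.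

Compound 4 `c1ccc(Cn2cncc2CNc2cccc(-c3cccnc3)c2)cc1` keeps the core of compound 1 and changes one group: pyridin-3-yl in place of 2,3-dimethylphenyl on an aromatic carbon. This puts pyridin-3-yl in place of 2,3-dimethylphenyl on an aromatic carbon. Within the data shown here, no measured pair shows what a change of this kind does in this assay, so the expectation rests on the three values alone. A modest step is expected, with neither direction favoured, and compound 4 is expected to stay in the range of these compounds. The estimated change is a step that the limit leaves unreadable from compound 1 to compound 4. For compound 4 the expected value is 8000 nM, with an estimated range from 2000 nM to 30000 nM.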

Compound 4, half-maximal effective concentration: > 1000 nM
Compound 4: no number, only a limit (the forecaster's own chance of this, stated with the estimate: 55%); the middle value lies beyond the limit too.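

In this assay, within the data shown here, compound 4 gives only a limit, > 1000 nM, and compound 1 also gives only a limit, so no step from compound 1 to compound 4 can be read. As far as these compounds go, what pyridin-3-yl in place of 2,3-dimethylphenyl does in this assay remains open.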